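Two amide caps, two chain lengths, one gap to fill

The compounds below may be only part of what the source reports. "The series", "measured", "known", "first", "only" and "open" are said of these compounds alone.

Compound 1 `CCCCCCCCCCCCCCNC(=O)[C@@H](NC(=O)c1cc2ccccc2n1C)[C@@H](C)O` and compound 2 `CCCCCCCCCCCCCCNC(=O)[C@@H](NC(=O)/C=C/c1ccccc1)[C@@H](C)O` share a core and differ only in the group on one carbonyl carbon: compound 2 differs from compound 1 by 2-phenylethenyl in place of 1-methyl-1H-indol-2-yl on a carbonyl carbon. In a functional assay on MCF7 cells (Homo sapiens) for cytotoxicity, read by MTT assay, with a stated time of 48 h (on this read-out higher numbers stand for weaker inhibition and lower numbers for stronger inhibition), compound 1 gives 25700 nM, and compound 2 gives 64600 nM, so this change produced a 2.5-fold higher number from compound 1 to compound 2 (0.40 log units; beyond the scatter). Compound 3 `CCCCCCCCCCCCCCCCCCNC(=O)[C@@H](NC(=O)c1cc2ccccc2n1C)[C@@H](C)O` differs from compound 1 by butyl in place of hydrogen on a saturated chain carbon, ten or more bonds along the chain from an amide-type nitrogen, and in this assay compound 3 gives 36400 nM, a move of a 1.4-fold higher number from compound 1 to compound 3 (0.15 log units; within the scatter). Compound 4 `CCCCCCCCCCCCCCCCCCNC(=O)[C@@H](NC(=O)/C=C/c1ccccc1)[C@@H](C)O` is not yet measured; it differs from compound 3 by 2-phenylethenyl in place of 1-methyl-1H-indol-2-yl on a carbonyl carbon, the same change seen between compound 1 and compound 2, occurring twice among these four compounds. Among the compounds with values here, because a 1.4-fold higher number from compound 1 to compound 3 (0.15 log units; within the scatter) is the only change that separates the two cores on which this replacement is made, the step from compound 3 to compound 4 is expected to be about the size of the earlier one, giving an expected 2.5-fold higher number from compound 3 to compound 4 (0.40 log units; beyond the scatter). Compound 4 is therefore estimated at 91000 nM, expected to fall between 45000 nM and 180000 nM.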

Compound 4, half-maximal inhibitory concentration: 39200 nM
Estimate against measurement, compound 4: 2.3-fold (0.37 log units) above; the whole stated range lies above it.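

On the longer chain, swapping 1-methyl-1H-indol-2-yl for 2-phenylethenyl gives a 1.1-fold higher number from compound 3 to compound 4 (0.03 log units; within the scatter) in this assay, and with the 2-phenylethenyl group in place, butyl in place of hydrogen on the chain gives a 1.6-fold lower number from compound 2 to compound 4 (0.22 log units; within the scatter). The swap looks larger on the shorter chain than on the longer one, but the two steps cannot be told apart, and this does not prove that the swap carries over unchanged: the same change on two cores in this assay, a 2.5-fold higher number (0.40 log units; beyond the scatter) from compound 1 to compound 2 and a 1.1-fold higher number (0.03 log units; within the scatter) from compound 3 to compound 4, 2.3-fold (0.37 log units) apart, within the scatter of two such steps. The chain change reads the same way, so these four compounds show neither a real dependence on the core nor a clean transfer from one core to the other: the same change on two cores in this assay, a 1.4-fold higher number (0.15 log units; within the scatter) from compound 1 to compound 3 and a 1.6-fold lower number (0.22 log units; within the scatter) from compound 2 to compound 4, 2.3-fold (0.37 log units) apart, within the scatter of two such steps.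

The compounds shown leave open how a shorter chain, such as decyl, would behave with either group on the carbonyl carbon. They also leave open whether a group carrying an amine or a carboxylic acid in that place would give a step beyond the scatter on both chains.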